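Amidine-to-imidazoline switch on a benzofuran series

A few compounds are considered here, and "the series" means these few. Any claim that something is new, unique, unknown or untested is made for them only; others in the source may bear on it.

Compound 1 `CC(C)NC(=N)c1ccc2oc(-c3ccc(OCCCCCOc4ccccc4)cc3)cc2c1` carries an open-chain amidine on the fused core; in an ADME assay on L6 cells (Rattus norvegicus) for cytotoxicity, read by resazurin assay, with a stated time of 70 h (a lower number here means a stronger inhibitor, a higher number a weaker inhibitor), compound 1 gives 20500 nM. Compound 2 `c1ccc(OCCCCCOc2ccc(-c3cc4cc(C5=NCCN5)ccc4o3)cc2)cc1` replaces that group by a cyclic one, (a group of 5 heavy atoms (3 carbon, 2 nitrogen; one five-membered non-aromatic ring with 2 hetero atoms) in place of a group of 6 heavy atoms (4 carbon, 2 nitrogen; no ring), on an aromatic carbon); in this assay compound 2 gives 900 nM, and this step gives a 23-fold lower number from compound 1 to compound 2 (1.36 log units; beyond the scatter). Compound 3 `CC(C)NC(=N)c1ccc2cc(-c3ccc(OCCCCCCOc4ccccc4)cc3)oc2c1` keeps the open-chain group of compound 1 on a differently attached core with a longer linker; the difference between the two cores is not broken down here. In this assay compound 3 gives 4900 nM, a lower number than compound 1 and a higher one than compound 2.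

Compound 4 `c1ccc(OCCCCCCOc2ccc(-c3cc4ccc(C5=NCCN5)cc4o3)cc2)cc1` is not yet measured. It stands to compound 3 as compound 2 stands to compound 1: a group of 5 heavy atoms (3 carbon, 2 nitrogen; one five-membered non-aromatic ring with 2 hetero atoms) in place of a group of 6 heavy atoms (4 carbon, 2 nitrogen; no ring), on an aromatic carbon, the same change at the same place. Going by the values given here, the only basis for an expectation is the single step of a 23-fold lower number from compound 1 to compound 2 (1.36 log units; beyond the scatter), so the estimate for compound 4 is a 16-fold lower number from compound 3 to compound 4 (1.21 log units; beyond the scatter). That expected step is tempered: one observation cannot fix the size of the step on the core of compound 3. For compound 4 the expected value in this assay is 300 nM, with a range from 100 nM to 1200 nM.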

Compound 4, half-maximal inhibitory concentration: 3400 nM
Estimate against measurement, compound 4: 11-fold (1.05 log units) below; measured number above the stated range.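

In this assay, replacing the open-chain group with the cyclic one on the core of compound 3 gives a 1.4-fold lower number from compound 3 to compound 4 (0.16 log units; within the scatter), so the large step seen on the core of compound 1 does not recur here. The same change therefore cannot be assumed to carry the same size from one core to the other: the same change on two cores in this assay, a 23-fold lower number (1.36 log units; beyond the scatter) from compound 1 to compound 2 and a 1.4-fold lower number (0.16 log units; within the scatter) from compound 3 to compound 4, 16-fold (1.20 log units) apart, beyond the scatter of two such steps

The two pairs differ both in how the core is attached and in linker length, so these results do not show which of the two sets the size of the step, and two pairs give no general rule for the series.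

Still open, as far as these compounds go, is whether the cyclic group would give a large or a small step on the core of compound 1 with the longer linker, or on the core of compound 3 with the shorter one. Also open, from the compounds shown here alone, is how an amine or a carboxylic acid on the same aromatic carbon would stand in this assay.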